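Cytotoxicity notes on amide-nitrogen substituents in a sulfone series

A few compounds are considered here, and "the series" means these few. Any claim that something is new, unique, unknown or untested is made for them only; others in the source may bear on it.

- Compound 1 `Cc1cc(C)cc(S(=O)(=O)c2c(C(=O)NC3CN(Cc4cccnc4)C3)[nH]c3ccc(Cl)cc23)c1`: 36000 nM
- Compound 2 `Cc1cc(C)cc(S(=O)(=O)c2c(C(=O)NC3CN(Cc4ccccc4F)C3)[nH]c3ccc(Cl)cc23)c1`: > 238000 nM (a limit)

In an ADME assay on MT4 cells (Homo sapiens) for cytotoxicity, read by MTT assay, with a stated time of 5 days (on this read-out higher numbers stand for lower toxicity in this test and lower numbers for higher toxicity in this test), compound 2 gives > 238000 nM, which is a limit and not a number. The change to compound 3 `Cc1cc(C)cc(S(=O)(=O)c2c(C(=O)NS(=O)(=O)C(F)(F)F)[nH]c3ccc(Cl)cc23)c1` is (trifluoromethyl)sulfonyl in place of 1-(2-fluorobenzyl)azetidin-3-yl on an amide-type nitrogen. Going by the values given here, the only measured step, an at least 6.6-fold higher number from compound 1 to compound 2 (0.82 log units; beyond the scatter), alters a group inside the part that leaves here, so it bears on this change only loosely. It does show that this substituent can move the read-out, and compound 1 gives 36000 nM. A move toward lower numbers is therefore expected, with the size uncertain. The expected change is an estimated at least 3.4-fold lower number from compound 2 to compound 3 (0.53 log units; beyond the scatter). Compound 3 is expected at about 70000 nM, with an estimated range of 15000 nM to 240000 nM.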

Compound 3, half-maximal cytotoxic concentration: 141000 nM
Beside the measured number, compound 3's estimate is 2.0-fold (0.30 log units) below it; the range from low to high includes it.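

With (trifluoromethyl)sulfonyl on the amide-type nitrogen, a substituent without a ring also reads toward lower toxicity in this assay, with a 3.9-fold higher number from compound 1 to compound 3 (0.59 log units; beyond the scatter). Against the 2-fluorobenzyl analogue the result is less clear, with an at least 1.6-fold lower number from compound 2 to compound 3 (0.22 log units; that floor lies within the scatter), so no real drop is established. The value for compound 2 is a limit and not a number: the limit of > 238000 nM in this assay, at which 1 of the 3 values shown sits.

Going by these compounds, whether a methylsulfonyl or acetyl group on this nitrogen reads like (trifluoromethyl)sulfonyl stays open. So does whether an azetidin-3-yl group with a free amine reads closer to compound 1 or compound 2.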